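Replacing a chloro aryl with a dimethyl aryl

The compounds below may be only part of what the source reports. "The series", "measured", "known", "first", "only" and "open" are said of these compounds alone.

Compounds measured so far:
compound 1, `COc1ccccc1-c1ccc2ncn(-c3cc(OC)c(OC)c(OC)c3)c2c1`, gives 4320 nM in a functional assay on A549 cells (Homo sapiens) for antiproliferative activity, read by MTT assay, with a stated time of 72 h; on this read-out lower numbers stand for stronger inhibition and higher numbers for weaker inhibition
compound 2, `COc1cc(-n2cnc3ccc(-c4ccccc4Cl)cc32)cc(OC)c1OC`, gives > 10000 nM in this assay
compound 3, `COc1cc(-n2cnc3ccc(-c4cccc(F)c4)cc32)cc(OC)c1OC`, gives 5270 nM in this assay

All three share the same core and differ only in the aryl ring attached to it. Compound 1 and compound 3 both give numbers, and a 1.2-fold higher number from compound 1 to compound 3 (0.09 log units; within the scatter). For compound 2 the result is a limit, > 10000 nM, not a number: compound 2 is the one case among the three that sits at the limit of > 10000 nM in this assay, at which 1 of the 3 values shown sits, so only a floor is known for it, and compound 2 stands as the weakest of the three on the numbers shown.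

Compound 4, `COc1cc(-n2cnc3ccc(-c4cccc(C)c4C)cc32)cc(OC)c1OC`, is not yet measured. The change from compound 2 is 2,3-dimethylphenyl in place of 2-chlorophenyl on an aromatic carbon. Among the compounds with values here, two measured steps bear on it: an at least 2.3-fold higher number from compound 1 to compound 2 (0.36 log units; beyond the scatter), and an at least 1.8-fold lower number from compound 2 to compound 3 (0.27 log units; that floor lies within the scatter). Both show that moving away from the 2-chlorophenyl has so far gone toward stronger inhibition, though the floor on compound 2 leaves the size of such a step uncertain. Within the data shown here, no measured compound carries two methyl groups, so the new ring is untested ground.

Compound 4 is expected at 7000 nM, with a range from 2500 nM to 10000 nM. This estimate means an expected step of an at least 1.4-fold lower number from compound 2 to compound 4 (0.15 log units; that floor lies within the scatter).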

Compound 4, half-maximal inhibitory concentration: 9250 nM
Estimate against measurement, compound 4: 1.3-fold (0.12 log units) below, within the range that was stated.
By their numbers in this assay, from the lowest: compounds 1, 3 and 4 (each within the scatter of the next, the first and the last beyond it). At a limit, above all of these: compound 2.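

With the 2,3-dimethylphenyl ring on the shared core, this assay gives a 2.1-fold higher number from compound 1 to compound 4 (0.33 log units; beyond the scatter), a modest step beyond the scatter, and also a 1.8-fold higher number from compound 3 to compound 4 (0.24 log units; within the scatter), which lies within it. Compound 4 therefore separates from compound 1, which carries the 2-methoxyphenyl ring, but not from compound 3, which carries the 3-fluorophenyl ring. The change from 2-chlorophenyl gives an at least 1.0-fold lower number from compound 2 to compound 4 (0.03 log units; that floor lies within the scatter), so no direction can be read from this step, even though compound 4 has a number and compound 2 remains a limit: the limit of > 10000 nM in this assay, at which 1 of the 4 values shown sits.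

The compounds shown leave open whether an amine or a carboxylic acid on this aryl ring would bring the number in this assay down. They also leave open how each methyl group of compound 4 contributes, since a phenyl ring with a single methyl group or with a longer chain such as propyl does not appear among them.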